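Swapping a pyridine for a thiophene on a shared core

A few compounds are considered here, and "the series" means these few. Any claim that something is new, unique, unknown or untested is made for them only; others in the source may bear on it.

Compound 1 `Oc1ccc(-c2cc(-c3ccc(Cl)cc3)nc(-c3cccnc3)c2)cc1` is a three-ring molecule tested in a functional assay on HCT-15 cells (Homo sapiens) for cytotoxicity, read by CCK-8 assay and cell counting, with a stated time of 2 days; a lower number here means a stronger inhibitor, a higher number a weaker inhibitor; compound 1 gives 20700 nM. Compound 2 `Oc1ccc(-c2cc(-c3ccc(Cl)cc3)nc(-c3cccs3)c2)cc1` differs from it by thiophen-2-yl in place of pyridin-3-yl on an aromatic carbon, and in this assay compound 2 gives 6470 nM. That change made a step of a 3.2-fold lower number from compound 1 to compound 2 (0.51 log units; beyond the scatter).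

Compound 3 `Oc1cccc(-c2cc(-c3cccnc3)nc(-c3ccccc3Cl)c2)c1` has the same atoms as compound 1, joined differently; the difference between the two cores is not broken down here. In this assay compound 3 gives "not determined" (no result reported), so no result is reported for it. Compound 4 `Oc1cccc(-c2cc(-c3cccs3)nc(-c3ccccc3Cl)c2)c1` differs from compound 3 by thiophen-2-yl in place of pyridin-3-yl on an aromatic carbon. Among the measured compounds shown here, this is the same kind of change as the one from compound 1 to compound 2, but the surroundings differ: in compound 3 the site is meta to a 2-chlorophenyl group and meta to a 3-hydroxyphenyl group, whereas in compound 1 it is meta to a 4-chlorophenyl group and meta to a 4-hydroxyphenyl group.

With no value for compound 3, the expectation for compound 4 rests on compound 2, which carries the same thiophen-2-yl group and gives 6470 nM. Compound 4 is therefore estimated at 8000 nM, expected to fall between 2000 nM and 40000 nM.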

Compound 4, half-maximal inhibitory concentration: 2790 nM
For compound 4 the middle estimate is 2.9-fold (0.46 log units) above the measured one; the measured number falls inside the stated range.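

In this assay, among the compounds shown here, compound 3 has no number to set against compound 4, which gives 2790 nM, so no step between the two can be read. From the compounds shown here alone, whether thiophen-2-yl in place of pyridin-3-yl changes the number on this core as it did on the core of compound 1 stays open. No supporting data bear on this result.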